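Compound 2 and its 4-fluorophenyl analogue

This account rests on a few compounds, and the source may have more. Where it says the series, first, only, none or still open, it means among the compounds named here.

Measured in a functional assay on HepG2 cells (Homo sapiens) for antiproliferative activity, read by MTT assay, with a stated time of 24 h; a higher number here means a weaker inhibitor, a lower number a stronger inhibitor:
Compound 1 `Cc1ccc(-c2nn(-c3ccccc3)cc2-c2nc3ccccc3n2S(=O)(=O)c2cc(C)ccc2C)cc1` gives 460 nM
Compound 2 `Cc1ccc(-c2nn(-c3ccccc3)cc2-c2nc3ccccc3n2S(=O)(=O)c2ccc(F)cc2)cc1` gives 5060 nM
Compound 3 `Cc1ccc(-c2nn(-c3ccccc3)cc2-c2nc3ccccc3n2S(=O)(=O)c2ccc(C(F)(F)F)cc2)cc1` gives 1930 nM

Compound 2 holds the highest number of the three: an 11-fold higher number from compound 1 to compound 2 (1.04 log units; beyond the scatter), and a 2.6-fold lower number from compound 2 to compound 3 (0.42 log units; beyond the scatter). Compound 4 `O=S(=O)(c1ccc(F)cc1)n1c(-c2cn(-c3ccccc3)nc2-c2ccc(F)cc2)nc2ccccc21` is the next to read. It departs from compound 2 by fluoro in place of methyl on an aromatic carbon, 4-methylphenyl becoming 4-fluorophenyl. Going by the values given here, no measured step touches that place. All three concern the group on the sulfonyl sulfur, and the closest in kind, a swap on an aromatic carbon, is the modest 2.6-fold lower number from compound 2 to compound 3 (0.42 log units; beyond the scatter). The expected step is a 1.1-fold lower number from compound 2 to compound 4 (0.05 log units; within the scatter), within the scatter, with no direction favoured. For compound 4 the estimated value is 4500 nM, with an expected range from 1800 nM to 11000 nM.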

Compound 4, half-maximal inhibitory concentration: 3520 nM
Compound 4: middle estimate off by 1.3-fold (0.11 log units), on the high side; low and high end bracket the measured number.
By their numbers in this assay, from the lowest: compound 1; then compounds 3, 4 and 2 (each within the scatter of the next, the first and the last beyond it).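

Read in this assay the only change shown away from the sulfonyl sulfur, 4-methylphenyl to 4-fluorophenyl, is a 1.4-fold lower number from compound 2 to compound 4 (0.16 log units; within the scatter) and so stays within the scatter. With 4-fluorophenyl on the sulfonyl sulfur, this place para to a large group therefore shows no clear response to fluoro in place of methyl, whereas all three swaps on the sulfonyl side lie beyond the scatter. No evidence available here bears on this result.

On these data alone, whether an amine or a methoxy group at this place would read differently stays open. So does whether fluoro in place of methyl reads the same with the 2,5-dimethylphenyl group of compound 1 on the sulfonyl sulfur.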